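Chloro to methoxy exchange across two cores in cytotoxicity

A few compounds are considered here, and "the series" means these few. Any claim that something is new, unique, unknown or untested is made for them only; others in the source may bear on it.

Compound 1 `O=C(O)c1cn(C2CC2)c2c(Cl)c(N3CCCC3)c(F)cc2c1=O` is taken as the reference. In a functional assay on V79 cells (Cricetulus griseus) for cytotoxicity, read by colony formation (on this read-out lower numbers stand for stronger inhibition and higher numbers for weaker inhibition), compound 1 gives 150 ug/mL. Compound 2 `COc1c(N2CCCC2)c(F)cc2c(=O)c(C(=O)O)cn(C3CC3)c12` differs from compound 1 only at one aromatic carbon, the difference being (methoxy in place of chloro on an aromatic carbon); in this assay compound 2 gives 150 ug/mL, which is no change at the digits printed from compound 1 to compound 2 (within the scatter). Compound 3 `CC1CN(c2c(F)cc3c(=O)c(C(=O)O)cn(C4CC4)c3c2Cl)CC(C)N1` carries a second core, differing from compound 1 by 3,5-dimethylpiperazin-1-yl in place of pyrrolidin-1-yl on an aromatic carbon; in this assay compound 3 gives 140 ug/mL, and the step is a 1.1-fold lower number from compound 1 to compound 3 (0.03 log units; within the scatter). All three values sit within the scatter of one another, so no order among them can be read.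

Compound 4 `COc1c(N2CC(C)NC(C)C2)c(F)cc2c(=O)c(C(=O)O)cn(C3CC3)c12` is not yet measured. It stands to compound 3 as compound 2 stands to compound 1: the change is methoxy in place of chloro on an aromatic carbon. The surroundings of the place are not identical, however: in compound 1 the aromatic carbon is ortho to a pyrrolidin-1-yl group (5 heavy atoms), whereas in compound 3 it is ortho to a 3,5-dimethylpiperazin-1-yl group (8 heavy atoms); the rest of the place line is the same, so this is the same kind of change rather than the same change. On the first core the change gave no change at the digits printed from compound 1 to compound 2 (within the scatter). For the measured compounds named here, with only that one precedent, the step for compound 4 in this assay is expected to be no change at the digits printed from compound 3 to compound 4 (within the scatter), resting on the fact that compound 1 gave 150 ug/mL and compound 2 gave 150 ug/mL. Compound 4 is therefore estimated at 140 ug/mL, with a likely range of 70 ug/mL to 280 ug/mL.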

Compound 4, half-maximal inhibitory concentration: > 500 ug/mL
Compound 4: a limit, no number; the forecaster's own chance of this, stated with the estimate: 10%; middle value at least 3.5-fold (0.55 log units) away from the limit.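

Compound 4 gives > 500 ug/mL in this assay, which is a limit of the assay and not a number.

The methoxy for chloro exchange therefore does not carry over unchanged from the core of compound 1 to the core of compound 3, as it now gives an at least 3.5-fold higher number from compound 3 to compound 4 (0.55 log units; beyond the scatter): the same change on two cores in this assay, no change at the digits printed (within the scatter) from compound 1 to compound 2 and an at least 3.5-fold higher number (0.55 log units; beyond the scatter) from compound 3 to compound 4, at least 3.5-fold (0.55 log units) apart, beyond the scatter of two such steps

The amine exchange read between the two methoxy compounds, an at least 3.3-fold higher number from compound 2 to compound 4 (0.52 log units; beyond the scatter), departs in the same way from its chloro counterpart, which shows that the two changes do not act independently in these four compounds but does not show the full size of the gap, which stays open on one side, or whether it would recur beyond this single pair per core: the same change on two cores in this assay, a 1.1-fold lower number (0.03 log units; within the scatter) from compound 1 to compound 3 and an at least 3.3-fold higher number (0.52 log units; beyond the scatter) from compound 2 to compound 4, at least 3.5-fold (0.55 log units) apart, beyond the scatter of two such steps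

The compounds shown leave open whether the shift belongs to methoxy in particular or would also appear with a longer group such as ethoxy at the same aromatic carbon. They also leave open whether it needs the 3,5-dimethylpiperazin-1-yl group, since a smaller amine such as dimethylamino would test whether the pairing with methoxy holds for other amines on this carbon.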